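The compounds below may be only part of what the source reports. "The series", "measured", "known", "first", "only" and "open" are said of these compounds alone.

Measured so far:
compound 1 `CN(C)c1nc2c(C(=O)N[C@@H]3CN4CCC3CC4)cccc2o1` — 18.2 nM
compound 2 `CCN(CC)c1nc2c(C(=O)N[C@@H]3CN4CCC3CC4)cccc2o1` — 12.4 nM

Two compounds share one core and differ only in the amine on the aromatic carbon. In an assay on isolated protein for binding affinity to 5-hydroxytryptamine receptor 3A (Homo sapiens) (a lower number here means a stronger inhibitor, a higher number a weaker inhibitor), compound 1 gives 18.2 nM, and in this assay compound 2 gives 12.4 nM. Going by the values given here, the only step in hand is a 1.5-fold lower number from compound 1 to compound 2 (0.17 log units; within the scatter), so the two values sit within the usual scatter of one another and neither compound can be called the stronger binder; compound 2 simply shows the smaller of the two numbers.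

Compound 3 `CC(C)N(C)c1nc2c(C(=O)N[C@@H]3CN4CCC3CC4)cccc2o1` keeps the core and changes the amine once more: isopropyl(methyl)amino in place of diethylamino on an aromatic carbon. The same atoms are present, only joined differently, so the change is of the same kind as the one already measured, a swap between small dialkylamino groups on that aromatic carbon. That earlier swap, from compound 1 to compound 2, gave no step beyond the scatter. On this single precedent no shift beyond the scatter is expected in this assay either way, a step estimated as a 1.1-fold higher number from compound 2 to compound 3 (0.05 log units; within the scatter). Compound 3 is therefore estimated at 14 nM, with a range from 5 nM to 35 nM.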

Compound 3, inhibition constant: 66.5 nM
Beside the measured number, compound 3's estimate is 4.8-fold (0.68 log units) below it; measured number above the stated range.
By their numbers in this assay, from the lowest: compounds 2 and 1 (each within the scatter of the next); then compound 3.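

In this assay this position turns out to be sensitive to how the atoms of the amine are joined, not just to how many there are: going from diethylamino to isopropyl(methyl)amino gives a 5.4-fold higher number from compound 2 to compound 3 (0.73 log units; beyond the scatter) even though the heavy atoms, hydrogen-bond donors and hydrogen-bond acceptors count the same on both sides. Putting isopropyl in place of methyl on the nitrogen gives a 3.7-fold higher number from compound 1 to compound 3 (0.56 log units; beyond the scatter) as well, so compound 3 stands apart from both earlier compounds, whereas the swap from dimethylamino to diethylamino stayed within the scatter. Nothing among the data offers an explanation for this shift in either step.

From the compounds shown here alone, the pattern rests on compound 3 alone, so it remains open whether the higher number belongs to isopropyl specifically or would also appear with another group on that nitrogen, such as cyclopropyl or tert-butyl. Going by these compounds, it is equally open how amines with the nitrogen held in a ring, such as pyrrolidine or morpholine, would compare with the open-chain dialkylamino groups at this position.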